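Removing the 3-(dimethylamino)propyl group from compound 1

The compounds below may be only part of what the source reports. "The series", "measured", "known", "first", "only" and "open" are said of these compounds alone.

Compounds measured so far in a functional assay on HepG2 cells (Homo sapiens) for inhibition, read by MTT assay, with a stated time of 24 h (a higher number here means a weaker inhibitor, a lower number a stronger inhibitor), are:

- compound 1 `COc1ccc(Cc2nc(-c3cc(Br)c(OCCCN(C)C)c(Br)c3)cnc2Cl)cc1Br` with 63200 nM
- compound 2 `COc1ccc(Cc2nc(-c3cc(Br)c(O)c(Br)c3)c[nH]c2=O)cc1Br` with 146000 nM

Compound 1 holds the lower of these two numbers, making it the stronger inhibitor of the pair, and the gap between them lies beyond the scatter. Compound 3 `COc1ccc(Cc2nc(-c3cc(Br)c(O)c(Br)c3)cnc2Cl)cc1Br` has not yet been measured. It differs from compound 1 by a single change, hydrogen in place of 3-(dimethylamino)propyl on an oxygen on an aromatic ring, which turns 3-(dimethylamino)propoxy into hydroxy. Among the compounds with values here, no measured pair isolates this change, so the data do not give its size directly. A moderate move towards a higher number, meaning a weaker inhibitor, is nevertheless expected in this assay, starting from compound 1 (63200 nM). The expected size of this move is given by the estimated step (a 1.7-fold higher number from compound 1 to compound 3 (0.24 log units; within the scatter)). For compound 3 the estimated value is 110000 nM (expected range 40000 nM to 300000 nM).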

Compound 3, half-maximal inhibitory concentration: 25600 nM
For compound 3 the middle estimate is 4.3-fold (0.63 log units) above the measured one; the measured number lies below the stated range.
By their numbers in this assay, from the lowest: compound 3; then compound 1; then compound 2.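

In this assay, replacing the 3-(dimethylamino)propyl group on the oxygen on the aromatic ring with hydrogen gives a 2.5-fold lower number from compound 1 to compound 3 (0.39 log units; beyond the scatter) and so strengthens inhibition, a modest step but one beyond the scatter. Within the data shown here, this is the first pair among the compounds that isolates this position, and it shows that the full 3-(dimethylamino)propoxy chain is not needed for the activity of compound 1 in this cell assay, since the plain hydroxy compound 3 does better. The data shown offer no measurement that would explain the direction of this step.

From the compounds shown here alone, what remains open is whether any group on this oxygen can match or improve on the hydroxy of compound 3, since a single pair cannot separate the effect of losing the chain from the effect of gaining the free hydroxy. A methoxy group, a shorter chain ending in an amine, a longer chain or a carboxylic acid at this place would each help to show how the number in this assay follows what stands on the oxygen.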